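This account rests on a few compounds, and the source may have more. Where it says the series, first, only, none or still open, it means among the compounds named here.

Measured so far in an ADME assay on liver (Mesocricetus auratus) for metabolic stability, using microsomes; on this read-out higher numbers stand for fast clearance and lower numbers for slow clearance:
- Compound 1 `O=C(NCc1ccccc1)Nc1[nH]nc(-c2ccccn2)c1Cl`: > 400 mL.min-1.g-1, a limit
- Compound 2 `COc1ccccc1C(=O)Nc1[nH]nc(-c2ccccn2)c1C1CC1`: > 100 mL.min-1.g-1, a limit

Compound 2 thus stands at a limit of this assay, with no exact number. Compound 3 `O=C(NCc1ccccc1)Nc1[nH]nc(-c2ccccn2)c1C1CC1` has benzylamino in place of 2-methoxyphenyl on a carbonyl carbon. Compound 1 also carries benzylamino, and its result of > 400 mL.min-1.g-1 is likewise a limit. On that basis, clearance is expected to stay fast or rise, and the expected step is a step that the limit leaves unreadable from compound 2 to compound 3. Compound 3 is estimated at 300 mL.min-1.g-1, with an expected range of 100 mL.min-1.g-1 to 900 mL.min-1.g-1.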

Compound 3, intrinsic clearance in microsomes: > 400 mL.min-1.g-1
Compound 3 ended at the assay's limit; the forecaster's own chance of this, stated with the estimate: 60%; at least 1.3-fold (0.12 log units) between middle value and limit.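

Within the data shown here, compound 1, compound 2 and compound 3 all stand at limits in this assay, and no step from compound 1 or compound 2 to compound 3 can be read. On these data alone, the actual clearance of all three compounds remains open, as does the size of either exchange.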